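Swapping a Chloropropyl Chain for Trichloromethyl

This account rests on a few compounds, and the source may have more. Where it says the series, first, only, none or still open, it means among the compounds named here.

Compound 1 `O=C(CCCl)Nc1ccc(SCC(=O)Nc2ccc(Br)cn2)cc1`: 1600 nM
Compound 2 `O=C(CCCCl)Nc1ccc(SCC(=O)Nc2ccc(Cl)cn2)cc1`: > 80000 nM

In a functional assay on NCI-H460 cells (Homo sapiens) for antiproliferative activity, read by MTT assay, with a stated time of 48 h (on this read-out lower numbers stand for stronger inhibition and higher numbers for weaker inhibition), compound 1 gives 1600 nM. For compound 2 the entry of > 80000 nM is a limit of the assay, not a measured number. From the compounds shown here alone, compound 2 therefore sits at the limit of > 80000 nM in this assay, at which 1 of the 2 values shown sits, and how far beyond that edge it lies is unknown. The two measured compounds differ in more than one place, so no single step can be read between them; their values simply stand as shown.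

Compound 3 `O=C(CSc1ccc(NC(=O)C(Cl)(Cl)Cl)cc1)Nc1ccc(Cl)cn1` has not yet been tested. It differs from compound 2 in one place: trichloromethyl in place of 3-chloropropyl on a carbonyl carbon. Among the measured compounds shown here, no measured pair shows this change, so its size and direction cannot be taken from the data, and the starting point is itself only a limit. Compound 3 is expected to give about 20000 nM, within a wide range from 2000 nM to 80000 nM. This estimate corresponds to an expected step of an at least 4.0-fold lower number from compound 2 to compound 3 (0.60 log units; beyond the scatter) in this assay.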

Compound 3, half-maximal inhibitory concentration: > 80000 nM
Compound 3 gave a limit, no number; the forecaster's own chance of this, stated with the estimate: 40%; middle value at least 4.0-fold (0.60 log units) from the limit.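

In this assay compound 3 gives > 80000 nM, which is a limit and not a number. Compound 2 also ends at a limit, so no step can be read between the two: the limit of > 80000 nM in this assay, at which 2 of the 3 values shown sit.

From the compounds shown here alone, whether trichloromethyl in place of 3-chloropropyl on a carbonyl carbon changes activity at all stays open.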